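Swapping the Benzyl Substituent: Fluoro Out, Methoxy In

This account rests on a few compounds, and the source may have more. Where it says the series, first, only, none or still open, it means among the compounds named here.

Measured so far:
compound 1, `CCOC(=O)c1ccc(-c2nn(Cc3ccccc3Cl)c3ccccc23)cc1`, 230 nM
compound 2, `CCOC(=O)c1ccc(-c2nn(Cc3ccccc3F)c3ccccc23)cc1`, 110 nM
compound 3, `CCOC(=O)c1ccc(-c2nn(Cc3ccc(F)cc3)c3ccccc23)cc1`, 190 nM

These three compounds share one core and differ only in the group carried on the saturated chain carbon bound to an aromatic nitrogen. In a functional assay on cells (Platelet, Homo sapiens) for inhibition (on this read-out higher numbers stand for weaker inhibition and lower numbers for stronger inhibition), compound 3 gives 190 nM, the second highest of the three numbers; its nearest neighbour is compound 1, with a 1.2-fold lower number from compound 1 to compound 3 (0.08 log units; within the scatter), and compound 2 sits further off, with a 1.7-fold higher number from compound 2 to compound 3 (0.24 log units; within the scatter), both within the usual scatter. Compound 4, `CCOC(=O)c1ccc(-c2nn(Cc3cccc(OC)c3)c3ccccc23)cc1`, carries 3-methoxyphenyl in place of 4-fluorophenyl on a saturated chain carbon bound to an aromatic nitrogen. Within the data shown here, no measured step involves a methoxy group. The steps that come closest are those that change the halogen on this ring: a 1.7-fold higher number from compound 2 to compound 3 (0.24 log units; within the scatter) and a 1.2-fold lower number from compound 1 to compound 3 (0.08 log units; within the scatter) lie within the scatter, while a 2.1-fold lower number from compound 1 to compound 2 (0.32 log units; beyond the scatter) is modest. Changing the group on this ring has so far given little movement, so the expected step is no change at the digits printed from compound 3 to compound 4 (within the scatter), none beyond the scatter. Compound 4 is therefore estimated at 190 nM in this assay, with a range from 80 nM to 450 nM.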

Compound 4, half-maximal inhibitory concentration: 260 nM
Beside the measured number, compound 4's estimate is 1.4-fold (0.14 log units) below it; low and high end bracket the measured number.
By their numbers in this assay, from the lowest: compounds 2, 3, 1 and 4 (each within the scatter of the next, the first and the last beyond it).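

Compound 4 puts an oxygen-bearing 3-methoxyphenyl group at this position, on the saturated chain carbon bound to an aromatic nitrogen, in place of a halogen-bearing ring. In this assay, the change leaves the number level with two of the halogen compounds, with a 1.4-fold higher number from compound 3 to compound 4 (0.14 log units; within the scatter) and a 1.1-fold higher number from compound 1 to compound 4 (0.05 log units; within the scatter) both small enough to count as no real difference. Only the 2-fluorophenyl compound stays apart, with a 2.4-fold higher number from compound 2 to compound 4 (0.37 log units; beyond the scatter) as a modest gap, and no measurement here explains that gap.

On these data alone, what an amine or a carboxylic acid on this benzyl ring would do remains open. So does whether a methoxy group would give the same result at another place on the ring, since only one placement appears here.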